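This account rests on a few compounds, and the source may have more. Where it says the series, first, only, none or still open, it means among the compounds named here.

Measured so far:
Compound 1, `N#CC1=C(N)OC(c2c[nH]c3ccccc23)=C(C#N)C1c1ccc(Br)cc1`, gives 947 ug/mL in a functional assay; a lower number here means a stronger inhibitor, a higher number a weaker inhibitor.
Compound 2, `N#CC1=C(N)OC(c2c[nH]c3ccccc23)=C(C#N)C1c1ccc(F)cc1`, gives 960 ug/mL in this assay.

Within the data shown here, compound 2 stands with the highest of the two numbers, but its only neighbour, compound 1, sits within the scatter: the change a 1.0-fold higher number from compound 1 to compound 2 (0.01 log units; within the scatter) is too small to read as a difference, and the two compounds can only be called equal in this assay.

Compound 3, `N#CC1=C(N)OC(c2c[nH]c3ccccc23)=C(C#N)C1c1cccc2ccccc12`, has not yet been measured. It differs from compound 2 by naphthalen-1-yl in place of 4-fluorophenyl on a saturated ring carbon. Among the measured compounds shown here, no measured step bears directly on this change: the one step available, from compound 1 to compound 2, swaps one halogen for another on the aromatic ring and leaves the ring itself untouched, and it stayed within the scatter. With both measured compounds at nearly the same number, compound 3 is expected to land near them as well, giving an estimated step of a 1.1-fold lower number from compound 2 to compound 3 (0.03 log units; within the scatter). The estimate for compound 3 in this assay is therefore 900 ug/mL, within a range of 350 ug/mL to 2000 ug/mL.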

Compound 3, half-maximal inhibitory concentration: > 1000 ug/mL
Compound 3: a limit, no number (the forecaster's own chance of this, stated with the estimate: 10%); at least 1.1-fold (0.04 log units) between middle value and limit.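

Compound 3 gives no number in this assay, only a limit: the limit of > 1000 ug/mL in this assay, at which 1 of the 3 values shown sits.

All that can be read are floors, an at least 1.0-fold higher number from compound 2 to compound 3 (0.01 log units; that floor lies within the scatter) and an at least 1.0-fold higher number from compound 1 to compound 3 (0.02 log units; that floor lies within the scatter), and both stay within the scatter, so compound 3 cannot be told apart from the two halogenated compounds. Unlike the swap of one halogen for another, this change replaces the aromatic group on the saturated ring carbon itself, and naphthalen-1-yl brings no stronger inhibition there.

On these data alone, how far compound 3 really lies beyond its limit remains open. Also open, as far as these compounds go, is whether any group on this carbon can bring the number down, such as a phenyl ring carrying a carboxylic acid or an amine, or a plain methyl group in place of the aromatic ring.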